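Trimming a Side Chain: From Compound 2 to Compound 4

The compounds below may be only part of what the source reports. "The series", "measured", "known", "first", "only" and "open" are said of these compounds alone.

Three compounds have been measured in a functional assay on NCI-H460 cells (Homo sapiens) for antiproliferative activity, read by CCK-8 assay, with a stated time of 72 h, tested at 2 uM; a lower number here means a weaker effect, a higher number a stronger effect of the compound at the concentration tested:

Compound 1, `Cc1ccc(Nc2nc(Cl)nc3c2ncn3Cc2ccc(/C=C/C(=O)Nc3ccccc3N)cc2)cc1`, gives 31.3%.
Compound 2, `COC(CCn1cnc2c(NCc3ccc(C(=O)Nc4ccccc4N)cc3)nc(Cl)nc21)OC`, gives 43.7%.
Compound 3, `Nc1ccccc1NC(=O)c1ccc(Cn2cnc3c(NCc4ccccc4)nc(Cl)nc32)cc1`, gives 44.7%.

Among these three numbers compound 2 stands second highest. Compound 3 sits nearest to it, and the two values lie within the usual scatter of this assay, so no order between them can be claimed. Compound 1 lies furthest away, with a lower value, and that gap is beyond the scatter.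

Compound 4, `CCCn1cnc2c(NCc3ccc(C(=O)Nc4ccccc4N)cc3)nc(Cl)nc21`, has not yet been measured. It differs from compound 2 in one place: methyl in place of dimethoxymethyl on a saturated chain carbon, two bonds along the chain from an aromatic nitrogen. The shared core, the chloro substituent and the benzamide bearing the aminophenyl group are unchanged; only the chain on the aromatic nitrogen is shortened and stripped of its two oxygen atoms.

Within the data shown here, no measured pair shows this exact change, so there is nothing to copy from. With the parts of compound 2 that the other compounds share left intact, the step is expected to be small and in no clear direction, staying within the scatter. Compound 4 is therefore expected to give about 42%, most likely between 26% and 58%. The estimated step is a number 1.7 percentage points lower from compound 2 to compound 4 (within the scatter), which is within the scatter.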

Compound 4, a percentage reported as inhibition, at one concentration (the size of the read-out at that concentration, not a potency): 31%
Compound 4: the middle estimate sits 11 percentage points above what was measured; measured number inside the range.
By their numbers in this assay, from the lowest: compounds 4 and 1 (each within the scatter of the next); then compounds 2 and 3 (each within the scatter of the next).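

Before this result, no measured pair differed at this position, so nothing showed whether the side chain mattered. In this assay, putting methyl in place of dimethoxymethyl gives a number 12.7 percentage points lower from compound 2 to compound 4 (beyond the scatter), which shows that the read-out responds to a change on this saturated chain carbon, two bonds along the chain from an aromatic nitrogen. Nothing available explains why the number moves with this change.

On these data alone, compound 4 loses the oxygen atoms and chain length together, and whether either loss alone would matter stays open. Also open, as far as these compounds go, is what a longer plain chain such as pentyl, or a chain ending in a hydroxyl group or an amine, would give at this position.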